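The source may report more compounds than this note shows. Statements on the series, on what has been measured and on what is new or still open speak of the compounds shown alone.

Compound 1, `CCC(CC)N(CCN(C)C(=O)CCC(=O)O)Cc1cccc(C(=O)Nc2sc3c(c2C(=O)c2cnn(-c4ccc(Cl)c(C(F)(F)F)c4)c2)CCC(C)(C)C3)c1`, in an assay on isolated protein for inhibition of sodium-dependent phosphate transport protein 2B (Homo sapiens); on this read-out lower numbers stand for stronger inhibition and higher numbers for weaker inhibition: 38 nM
Compound 2, `CCC(CC)N(CCN(C)C(=O)CCC(=O)O)Cc1cccc(C(=O)Nc2sc3c(c2C(=O)c2cnn(-c4ccc(Cl)cc4)c2)CCC(C)(C)C3)c1`, in this assay: 36 nM

Among the compounds with values here, compound 1 and compound 2 cannot be told apart on these two numbers: the single measured step, a 1.1-fold lower number from compound 1 to compound 2 (0.02 log units; within the scatter), is within the scatter. Compound 3, `CCC(CC)N(CCN(C)C(=O)CCC(=O)NC(C)(C)C(=O)NCCN(C)C)Cc1cccc(C(=O)Nc2sc3c(c2C(=O)c2cnn(-c4ccc(Cl)c(C(F)(F)F)c4)c2)CCC(C)(C)C3)c1`, differs from compound 1 in one place: (1-((2-(dimethylamino)ethyl)carbamoyl)-1-methylethyl)amino in place of hydroxy on a carbonyl carbon. Within the data shown here, the one measured step, a change of a substituent on an aromatic carbon, concerns a different part of the molecule, so no measured step bears on this change. Among the measured compounds shown here, the only guidance is that the shared core, and the part that carries the change, are held in common by compound 1 and compound 2. Without a comparable measured step, the expected step of a 1.2-fold higher number from compound 1 to compound 3 (0.07 log units; within the scatter) is taken as none beyond the scatter. Compound 3 is therefore estimated at 45 nM, with a range from 15 nM to 140 nM.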

Compound 3, half-maximal inhibitory concentration: 48 nM
Estimate against measurement, compound 3: 1.1-fold (0.03 log units) below; the range from low to high includes it.
By their numbers in this assay, from the lowest: compounds 2, 1 and 3 (each within the scatter of the next).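

On a carbonyl carbon, (1-((2-(dimethylamino)ethyl)carbamoyl)-1-methylethyl)amino stands in place of hydroxy, 12 heavy atoms for 1, and this assay shows a 1.3-fold higher number from compound 1 to compound 3 (0.10 log units; within the scatter) for this change. Compound 1 and compound 3 cannot be told apart on these numbers, so at this position the hydroxy is not required for inhibition in the presence of this replacement, and a far larger group is accepted there. The data offer no measured explanation of why so large a change leaves the number within the scatter.

As far as these compounds go, whether a smaller group at this carbonyl carbon, such as a methyl ester or a plain primary amide, would read the same remains open. So does the question of whether the dimethylamino end of the new chain contributes anything, which a version ending in a simple methyl group would address.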